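Butyl in Place of Isopropyl on a Thiourea Nitrogen

The compounds below may be only part of what the source reports. "The series", "measured", "known", "first", "only" and "open" are said of these compounds alone.

Of the compounds shown here, two sharing one core have been measured so far. Compound 1, `CCCNC(=S)Nc1nc2ccc(OC(F)(F)F)cc2s1`, carries a propyl group on an amide-type nitrogen, while compound 2, `CC(C)NC(=S)Nc1nc2ccc(OC(F)(F)F)cc2s1`, carries isopropyl in that place. In a functional assay on Cortex (Rattus norvegicus, strain Sprague-Dawley) (on this read-out lower numbers stand for an effect already at smaller amounts and higher numbers for an effect only at larger amounts of compound), compound 1 gives 0.01 uM, and in the same read-out compound 2 gives 0.1 uM. Within the data shown here, compound 2 therefore stands at the higher of the two numbers, and the only measured step is a 10-fold higher number from compound 1 to compound 2 (1.00 log units; beyond the scatter).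

Compound 3, `CCCCNC(=S)Nc1nc2ccc(OC(F)(F)F)cc2s1`, has not yet been measured. It differs from compound 2 in one place: butyl in place of isopropyl on an amide-type nitrogen. Butyl, like the propyl of compound 1, is a straight chain, whereas isopropyl is not. Among the measured compounds shown here, the one measured step bears directly on this change: going from propyl to isopropyl raised the number, so going from isopropyl back to a straight chain is expected to lower it, landing near compound 1, with some uncertainty since butyl is not propyl. The step of a 5.0-fold lower number from compound 2 to compound 3 (0.70 log units; beyond the scatter) is therefore expected. Compound 3 is estimated at 0.02 uM, with a likely range from 0.005 uM to 0.1 uM.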

Compound 3, minimum effective concentration: 1 uM
Beside the measured number, compound 3's estimate is 50-fold (1.70 log units) below it, and the stated range ends below it.
By their numbers in this assay, from the lowest: compound 1; then compound 2; then compound 3.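

In this assay, the earlier pair could suggest that a straight chain on this amide-type nitrogen is what keeps the number low, but butyl in place of isopropyl gives a 10-fold higher number from compound 2 to compound 3 (1.00 log units; beyond the scatter) and so rules out that simple reading. Chain length matters at least as much as chain shape here: adding a single methyl to the end of the propyl chain gives a 100-fold higher number from compound 1 to compound 3 (2.00 log units; beyond the scatter), a larger rise than the change from propyl to isopropyl, which gave a 10-fold higher number from compound 1 to compound 2 (1.00 log units; beyond the scatter). Among these three compounds the position therefore tolerates little change from propyl, as both the branched group and the longer straight chain give higher numbers, although nothing shown here explains why.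

Three compounds cannot show whether propyl is a true best point or whether the number would stay as low with the shorter ethyl group, or whether it would keep climbing with a longer chain such as pentyl. From the compounds shown here alone, it also remains open how a small ring such as cyclopropyl or a chain ending in a hydroxyl group would behave on this nitrogen.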